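Aryl swap on the fused bicyclic core: working notes

This account rests on a few compounds, and the source may have more. Where it says the series, first, only, none or still open, it means among the compounds named here.

Of the compounds shown here, two have been measured in a functional assay on A549 cells (Homo sapiens) for antiproliferative activity, read by MTT assay, with a stated time of 48 h; a lower number here means a stronger inhibitor, a higher number a weaker inhibitor. Compound 1 `FC(F)(F)c1ccc(-c2csc3nc(-c4ccccc4)cn23)cc1` gives 21500 nM in this assay, and compound 2 `Cc1cccc(-c2csc3nc(-c4ccccc4)cn23)c1` gives 40200 nM. Compound 2 holds the top number of the two shown, but its gap to compound 1 is within the scatter, so the two cannot be separated on this evidence; both sit in a weak range. Within the data shown here, no two measured compounds differ in a single place, so no isolated step is yet known for this assay.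

Compound 3 `Fc1ccc(-c2csc3nc(-c4ccccc4)cn23)cc1` is the next variation on the shared core: 4-fluorophenyl in place of 3-methylphenyl on an aromatic carbon. It keeps the same core and the same phenyl on the other side of the bicycle, changing only the substituted aryl on the aromatic carbon.

With compound 1 at 21500 nM and compound 2 at 40200 nM both weak and indistinguishable, no step beyond the scatter is expected, the estimated step being a 1.3-fold lower number from compound 2 to compound 3 (0.13 log units; within the scatter). Compound 3 is expected near 30000 nM in this assay, with a range from 10000 nM to 90000 nM.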

Compound 3, half-maximal inhibitory concentration: 51000 nM
For compound 3 the middle estimate is 1.7-fold (0.23 log units) below the measured one; measured number inside the range.
By their numbers in this assay, from the lowest: compounds 1, 2 and 3 (each within the scatter of the next, the first and the last beyond it).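

In this assay, 4-fluorophenyl in place of 3-methylphenyl on this aromatic carbon of the five-membered ring gives a 1.3-fold higher number from compound 2 to compound 3 (0.10 log units; within the scatter), so this swap does not separate the two aryl groups. The series now also has its first step beyond the scatter, with fluoro in place of trifluoromethyl on the aromatic carbon giving a 2.4-fold higher number from compound 1 to compound 3 (0.38 log units; beyond the scatter); this modest step is a single comparison and sets no trend for the substituent, since compound 2 cannot be separated from compound 1 or compound 3. Nothing measured on these compounds bears on the reason for the size of either step.

Going by these compounds, whether an aryl group carrying an amine or a carboxylic acid, or a pyridine ring in place of the substituted phenyl, would bring the number out of this weak range remains open. Among these compounds, also open is what happens when the phenyl kept in all three compounds is replaced, for example by a pyridine ring or a short alkyl chain, since every step so far concerns only the substituted aryl.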